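Urea series: aryl substituent exchange from compound 2 to compound 4

The source may hold more compounds than are shown below. What is called first, only, known or untested is meant among the compounds shown, and "the series" means these compounds.

Compound 1, `Cc1cc(C)c(NC(=O)N(Cc2ccc(-c3ccccc3)nc2)C2CCCCCC2)c(C)c1`: 260 nM
Compound 2, `Cc1cc(C)c(NC(=O)N(Cc2ccc(N3CCN(C)CC3)cc2)C2CCCCCC2)c(C)c1`: 57 nM
Compound 3, `CSc1cc(C)nc(SC)c1NC(=O)N(Cc1ccccc1)Cc1cccc(-c2ccn(C)n2)c1`: 73 nM

Three compounds carry numbers in an assay on microsomes from intestine for inhibition of acyl-CoA:cholesterol acyltransferase (Oryctolagus cuniculus); a higher number here means a weaker inhibitor, a lower number a stronger inhibitor. Compound 2 holds the lowest of the three; compound 3 lies within the scatter of it, while compound 1 sits beyond the scatter, higher. Among the measured compounds shown here, no pair of measured compounds differs in a single place, so no calibrated step is at hand.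

Compound 4, `Cc1cc(C)c(NC(=O)N(Cc2ccc(-c3cc[nH]n3)cc2)C2CCCCCC2)c(C)c1`, is not yet measured. It differs from compound 2 in one place: 1H-pyrazol-3-yl in place of 4-methylpiperazin-1-yl on an aromatic carbon. For compound 4 the step of a 1.8-fold higher number from compound 2 to compound 4 (0.24 log units; within the scatter) is expected to be a modest rise in this assay, roughly at the edge of the scatter. Compound 4 is therefore estimated at 100 nM, with a range from 35 nM to 300 nM.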

Compound 4, half-maximal inhibitory concentration: 52 nM
The estimate for compound 4 lay 1.9-fold (0.28 log units) above the measured number, and the stated range covers the measured number.
By their numbers in this assay, from the lowest: compounds 4, 2 and 3 (each within the scatter of the next); then compound 1.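

In this assay, among the compounds shown here, the step of a 1.1-fold lower number from compound 2 to compound 4 (0.04 log units; within the scatter) is the first calibrated step, and it lies within the scatter. On this aromatic carbon, para to a large group, a six-membered non-aromatic ring with no hydrogen-bond donor and a five-membered aromatic ring with one hydrogen-bond donor give no readable difference. Nothing measured here accounts for this match.

Open, as far as these compounds go, is whether the hydrogen on the 1H-pyrazol-3-yl ring matters, tested by its N-methyl counterpart. Also open, from the compounds shown here alone, is how a carboxylic acid or a small open-chain amine would fare at this position.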